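The source may report more compounds than this note shows. Statements on the series, on what has been measured and on what is new or still open speak of the compounds shown alone.

Of the compounds shown here, two that share one core have been measured in a functional assay on cells for positive allosteric modulation of metabotropic glutamate receptor 2 (Homo sapiens), read by fluorescence and calcium flux, with a stated time of 30 min; a higher number here means that more compound is needed for the effect, a lower number that less compound is needed. Compound 1 `Fc1ccc(-c2ccc(Cn3nnc4ccccc43)cc2)c(F)c1` gives 71 nM. Compound 2 `Fc1cc(Cl)ccc1-c1ccc(Cn2nnc3ccccc32)cc1` gives 28 nM, the lowest of the two numbers, and compound 1 is its nearest neighbour. Within the data shown here, the one change between them, chloro in place of fluoro on an aromatic carbon, brought a 2.5-fold lower number from compound 1 to compound 2 (0.40 log units; beyond the scatter). Compound 3 `Fc1cc(C(F)(F)F)ccc1-c1ccc(Cn2nnc3ccccc32)cc1` has not yet been measured. It differs from compound 2 by trifluoromethyl in place of chloro on an aromatic carbon, meta to a fluoro group and para to a large group. Among the measured compounds shown here, the only measured step at this position is the modest one just described, so a further exchange there is expected to move the number little, perhaps slightly downward, giving an expected step of a 1.3-fold lower number from compound 2 to compound 3 (0.10 log units; within the scatter). Compound 3 is therefore estimated at 22 nM, with a range from 8 nM to 60 nM.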

Compound 3, half-maximal effective concentration: 29 nM
The estimate for compound 3 lay 1.3-fold (0.12 log units) below the measured number, and the stated range covers the measured number.
By their numbers in this assay, from the lowest: compounds 2 and 3 (each within the scatter of the next); then compound 1.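

In this assay, the position para to a large group now carries a third group, and trifluoromethyl, with four heavy atoms in place of the single atom of chloro, reads level with chloro (a 1.0-fold higher number from compound 2 to compound 3 (0.02 log units; within the scatter)). Set against fluoro, trifluoromethyl gives a 2.4-fold lower number from compound 1 to compound 3 (0.39 log units; beyond the scatter), so chloro and trifluoromethyl each stand apart from fluoro by a step beyond the scatter, although the two differ in size. These numbers show that difference but do not explain it, and no other data bear on the result.

From the compounds shown here alone, it remains open whether a methoxy group, a nitrile, an amine or a carboxylic acid at this position would read like chloro and trifluoromethyl or like fluoro. Going by these compounds, it is also open how a plain hydrogen there would compare with these three groups.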